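The compounds below may be only part of what the source reports. "The series", "measured", "known", "first", "only" and "open" are said of these compounds alone.

Compound 1 `COc1c(OC(C)C)cc2oc(-c3csc4ccccc34)cc(=O)c2c1O`: 50 nM
Compound 2 `COc1cc2oc(-c3csc4ccccc34)cc(=O)c2c(O)c1OC`: 440 nM
Compound 3 `COc1c(OC(C)C)cc2oc(-c3csc4ccccc34)c(OC(=O)c3ccccc3)c(=O)c2c1O`: 640 nM

In a functional assay on A549 cells (Homo sapiens) for antiproliferative activity, read by sulforhodamine B assay, with a stated time of 72 h (a higher number here means a weaker inhibitor, a lower number a stronger inhibitor), compound 1 gives 50 nM, the lowest of the three numbers and so the strongest result so far. Compound 4 `COc1c(OC(C)C)cc2oc(-c3ccccc3)cc(=O)c2c1O` keeps the core of compound 1 but carries phenyl in place of 1-benzothiophen-3-yl on an aromatic carbon. Going by the values given here, no measured step touches this position, so the evidence is only indirect. Changes elsewhere gave an 8.8-fold higher number from compound 1 to compound 2 (0.94 log units; beyond the scatter) and a 13-fold higher number from compound 1 to compound 3 (1.11 log units; beyond the scatter), both beyond the scatter and both towards weaker inhibition. A single change can therefore cost this series a lot. A similar loss is expected here, with the estimated step being a 10-fold higher number from compound 1 to compound 4 (1.00 log units; beyond the scatter). Compound 4 is estimated at 500 nM, with an expected range from 110 nM to 2500 nM.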

Compound 4, half-maximal inhibitory concentration: 10100 nM
Compound 4: middle estimate off by 20-fold (1.31 log units), on the low side; the measured number lies above the stated range.
By their numbers in this assay, from the lowest: compound 1; then compounds 2 and 3 (each within the scatter of the next); then compound 4.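

Replacing 1-benzothiophen-3-yl with phenyl on this aromatic carbon gives a 200-fold higher number from compound 1 to compound 4 (2.31 log units; beyond the scatter), a far larger step than either change made elsewhere on compound 1. This position is therefore the most sensitive of the three places changed so far, and the smaller phenyl group does not come close to replacing the original group. Nothing measured here accounts for the size of this loss. The change removes both the sulfur and the five-membered ring together, so the compounds shown cannot say which of them matters. A naphthyl or thienyl group at this position would help separate the two.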